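A few compounds are considered here, and "the series" means these few. Any claim that something is new, unique, unknown or untested is made for them only; others in the source may bear on it.

Working notes on the series in a functional assay on cells (Neutrophil, Homo sapiens) for inhibition, with a stated time of 5 min; a higher number here means a weaker inhibitor, a lower number a stronger inhibitor. The smallest member, compound 1 `COc1cc(O)cc(CCc2ccccc2)c1`, gives only a limit in this assay, > 10000 nM, which is the assay limit and not a number (the limit of > 10000 nM in this assay, at which 1 of the 3 values shown sits). Compound 2 `COc1cc(CCc2cccc(O)c2)cc(O)c1Cc1ccc(O)cc1` carries one 4-hydroxybenzyl group and gives 900 nM in this assay. Compound 3 `COc1cc(CCc2cccc(O)c2)c(Cc2ccc(O)cc2)c(O)c1Cc1ccc(O)cc1` carries two 4-hydroxybenzyl groups and gives 1100 nM in this assay. Among the two numbers shown, compound 3 is the one with the higher value, but the step of a 1.2-fold higher number from compound 2 to compound 3 (0.09 log units; within the scatter) lies within the scatter, so compound 2 and compound 3 are not separated.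

Compound 4 `COc1cc(O)c(Cc2ccc(O)cc2)c(CCc2cccc(O)c2)c1` is the next member; relative to compound 3 the change is hydrogen in place of 4-hydroxybenzyl on an aromatic carbon. Going by the values given here, only one measured step bears on this: the step of a 1.2-fold higher number from compound 2 to compound 3 (0.09 log units; within the scatter), in which a 4-hydroxybenzyl group was added on an aromatic carbon without a change beyond the scatter. The removal of a 4-hydroxybenzyl group from compound 3, although at a different place, is therefore expected to give no step beyond the scatter in this assay. Compound 4 is expected to come out at 1000 nM, within 400 nM to 2500 nM, meaning an estimated step of a 1.1-fold lower number from compound 3 to compound 4 (0.04 log units; within the scatter).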

Compound 4, half-maximal inhibitory concentration: 2200 nM
Compound 4: the middle estimate sits 2.2-fold (0.34 log units) below what was measured, within the range that was stated.
By their numbers in this assay, from the lowest: compounds 2, 3 and 4 (each within the scatter of the next, the first and the last beyond it). At a limit, above all of these: compound 1.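

In this assay, taking the 4-hydroxybenzyl group off the aromatic carbon ortho to a hydroxy group and ortho to a methoxy group gives a 2.0-fold higher number from compound 3 to compound 4 (0.30 log units; within the scatter), so compound 3 and compound 4 are not separated at this position. Going by these compounds alone, the earlier step, a 1.2-fold higher number from compound 2 to compound 3 (0.09 log units; within the scatter), concerned a 4-hydroxybenzyl group on a different aromatic carbon, so this is the first reading at this place, and the two single changes now agree in not separating their pairs of compounds. Nothing among the data shown speaks to what lies behind this step.

The compounds shown leave open whether the hydroxy group of the 4-hydroxybenzyl group counts at this carbon, which a plain benzyl or a 4-methoxybenzyl group in the same place would test. They also leave open how a smaller or differently charged substituent would read here, such as a methyl group, an aminomethyl group or a carboxylic acid, and whether any of these would give a step beyond the scatter.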